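Writhing inhibition in the series: estimate for compound 4

This account rests on a few compounds, and the source may have more. Where it says the series, first, only, none or still open, it means among the compounds named here.

Measured so far:
Compound 1, `COc1ccc(C2=NN(C(=O)NS(=O)(=O)c3ccc(Cl)cc3)CC2c2ccccc2)c(OC)c1`: 0%
Compound 2, `CCOC(=O)c1nn(-c2ccc(Cl)cc2)c(-c2ccc(OC)cc2OC)c1C`: 0%
Compound 3, `COc1ccc(-c2c(C)c(C(=O)O)nn2-c2ccc(Cl)cc2)c(OC)c1`: 0%

In a functional assay on the whole organism for inhibition, with Mus musculus as the target, in the writhing test, with stated times of 30 min and 4 h, at a dose of 25 mg/kg by the intraperitoneal route (a lower number here means less inhibition, a higher number more inhibition at the dose given (going by the name of the read-out)), compound 1, compound 2 and compound 3 all give the same reading, and compound 3 stands level with both at the digits shown. Going by the values given here, the one single-point step, no change at the digits printed from compound 2 to compound 3 (within the scatter), is flat within the scatter.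

Compound 4, `COc1ccc(-c2c(-c3ccccc3)c(C(=O)O)nn2-c2ccc(Cl)cc2)c(OC)c1`, differs from compound 3 by phenyl in place of methyl on an aromatic carbon. Among the compounds with values here, no measured step exchanges methyl for phenyl, so the only guide is that every measured compound shows no inhibition and the one known step is flat. The expected step of a number 5 percentage points higher from compound 3 to compound 4 (within the scatter) is therefore none beyond the scatter. Compound 4 is estimated at 5%, with a range from 0% to 25%.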

Compound 4, a percentage reported as inhibition, in the whole organism at one dose (the size of the read-out at that dose, not a potency): 20%
Compound 4: middle estimate off by 15 percentage points, on the low side; the measured number falls inside the stated range.
By their numbers in this assay, from the lowest: compounds 1, 2 and 3 (each within the scatter of the next); then compound 4.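

Phenyl in place of methyl on this aromatic carbon gives a number 20 percentage points higher from compound 3 to compound 4 (beyond the scatter) in this assay and is the first step in the series beyond the scatter. Compound 1, compound 2 and compound 3 read level, so this position is the first place shown where a change moves the reading. No measurement here accounts for the step.

Open, on these data alone, is whether cyclohexyl or a butyl chain on this carbon would give the same reading as phenyl. Also open, as far as these compounds go, is whether phenyl here would carry over to the ethyl ester.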